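Swapping bromine for iodine on a dichloroacetanilide

The compounds below may be only part of what the source reports. "The series", "measured", "known", "first", "only" and "open" are said of these compounds alone.

Two small amides have been tested in a functional assay on A549 cells (Homo sapiens) for antiproliferative activity, read by MTT assay, with a stated time of 72 h; on this read-out lower numbers stand for stronger inhibition and higher numbers for weaker inhibition. Compound 1, `O=C(Nc1ccccc1)C(Cl)Cl`, is the unsubstituted parent; in this assay compound 1 gives 130000 nM. Compound 2, `O=C(Nc1ccc(Br)cc1)C(Cl)Cl`, carries a bromine on the ring; in this assay compound 2 gives 13700 nM. Among the compounds with values here, the single step between them, a 9.5-fold lower number from compound 1 to compound 2 (0.98 log units; beyond the scatter), is the only measured change available, and it leaves compound 2 with the lowest number of the two, with compound 1 the nearest at a clearly higher number.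

Compound 3, `O=C(Nc1ccc(I)cc1)C(Cl)Cl`, is the next member: iodo in place of bromo on an aromatic carbon, on an aromatic carbon of a six-membered aromatic ring of carbon only, para to a group of 6 heavy atoms. Within the data shown here, the one measured step bears on this change only loosely, since it describes adding a halogen rather than exchanging one halogen for a heavier one. A smaller shift in the same direction, or none beyond the scatter, is therefore expected. Compound 3 is expected to give about 8000 nM, within a range of 3000 nM to 25000 nM. This estimate corresponds to a step of a 1.7-fold lower number from compound 2 to compound 3 (0.23 log units; within the scatter).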

Compound 3, half-maximal inhibitory concentration: 12500 nM
For compound 3 the middle estimate is 1.6-fold (0.19 log units) below the measured one; low and high end bracket the measured number.
By their numbers in this assay, from the lowest: compounds 3 and 2 (each within the scatter of the next); then compound 1.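

In this assay the exchange of bromo for iodo on this aromatic carbon gives a 1.1-fold lower number from compound 2 to compound 3 (0.04 log units; within the scatter) and so separates the two halogens by no more than ordinary repeat variation. Measured against the unsubstituted parent, iodo in place of hydrogen gives a 10-fold lower number from compound 1 to compound 3 (1.02 log units; beyond the scatter) and bromo gives a 9.5-fold lower number from compound 1 to compound 2 (0.98 log units; beyond the scatter) so, in this small set, the clear drop in the number appears with both halogens, and the choice between them makes no measurable difference. Nothing on hand explains why compound 2 and compound 3 read alike, or why either differs from compound 1.

The compounds shown contain only hydrogen, bromo and iodo at this position, so it remains open whether the lighter halogens fluoro and chloro, or non-halogen groups such as methoxy, an amine or a carboxylic acid, would match the two heavier halogens or fall back towards compound 1. Also open, from the compounds shown here alone, is whether the drop would survive if the two chlorine atoms on the acyl side of the amide were replaced by hydrogen, since every compound here keeps both of them.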